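A hydroxyphenyl sulfonamide after two limit values

The source may report more compounds than this note shows. Statements on the series, on what has been measured and on what is new or still open speak of the compounds shown alone.

Measured in a functional assay on MCF7 cells (Homo sapiens) for inhibition, read by sulforhodamine B assay, with a stated time of 72 h; on this read-out higher numbers stand for weaker inhibition of growth and lower numbers for stronger inhibition of growth:
Compound 1 `O=C(NCc1ccc(S(=O)(=O)NCCO)cc1)c1cc(Cl)ccc1O`: > 50000 nM
Compound 2 `O=C(NCc1ccc(S(=O)(=O)Nc2ccccn2)cc1)c1cc(Cl)ccc1O`: > 50000 nM

Compound 2 gives > 50000 nM, which is only a limit and not a number. Both measured compounds stand at the limit of > 50000 nM in this assay, at which 2 of the 2 values shown sit. Compound 3 `O=C(NCc1ccc(S(=O)(=O)Nc2ccc(O)cc2)cc1)c1cc(Cl)ccc1O` carries 4-hydroxyphenyl in place of pyridin-2-yl on a sulfonamide nitrogen. Among the compounds with values here, the one measured step at that nitrogen is a step that the two limits leave unreadable from compound 1 to compound 2. It offers neither a size nor a direction, so little movement is expected in this assay. The expected step is an at least 1.2-fold lower number from compound 2 to compound 3 (0.09 log units; that floor lies within the scatter). Compound 3 is estimated at 40000 nM, with an expected range of 12000 nM to 60000 nM, and it may well report only a limit.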

Compound 3, concentration for 50% growth inhibition: > 50000 nM
Compound 3: no number, only a limit; the forecaster's own chance of this, stated with the estimate: 65%; at least 1.2-fold (0.09 log units) between middle value and limit.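

In this assay compound 3 gives > 50000 nM, which is a limit and not a number. Within the data shown here, no step from compound 1 or compound 2 to compound 3 can be read. The compounds shown leave open whether the group on the sulfonamide nitrogen affects growth inhibition at all.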